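A few compounds are considered here, and "the series" means these few. Any claim that something is new, unique, unknown or untested is made for them only; others in the source may bear on it.

Measured so far:
compound 1 `COc1ccc(C(c2ccc(OC)c(OC)c2)[C@H](C)[C@H](C)CO)cc1OC`: > 100000 nM
compound 2 `COc1cc(C(c2ccc(O)c(OC)c2)[C@H](CC(C)C)C(C)C)ccc1O`: 8200 nM

In a functional assay on HeLa cells (Homo sapiens) for cytotoxicity, read by WST assay, with a stated time of 48 h (on this read-out higher numbers stand for weaker inhibition and lower numbers for stronger inhibition), compound 1 reports only > 100000 nM, a limit rather than a number. Compound 1 thus sits at the limit of > 100000 nM in this assay, at which 1 of the 2 values shown sits. Among the measured compounds shown here, compound 2 gives 8200 nM, the only measured number in the set. Compound 3 `COc1cc(C(c2ccc(O)c(OC)c2)[C@@H](C)[C@@H](C)CF)ccc1O` differs from compound 2 in one place: 2-(fluoromethyl)-1-methylpropyl in place of 1-isopropyl-3-methylbutyl on a saturated chain carbon bound to two aromatic carbons. For the measured compounds named here, no comparable step between measured compounds exists, so the size of the change is uncertain; a loss of potency beyond the usual scatter is expected. Compound 3 is estimated at 25000 nM, within 8000 nM to 100000 nM, which means an expected step of a 3.0-fold higher number from compound 2 to compound 3 (0.48 log units; beyond the scatter).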

Compound 3, half-maximal inhibitory concentration: 42000 nM
Compound 3: the middle estimate sits 1.7-fold (0.23 log units) below what was measured, and the stated range covers the measured number.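

On the saturated chain carbon bound to two aromatic carbons, 2-(fluoromethyl)-1-methylpropyl in place of 1-isopropyl-3-methylbutyl gives a 5.1-fold higher number from compound 2 to compound 3 (0.71 log units; beyond the scatter) in this assay. This first readable step shows that the group at this position matters, though compound 3 still gives a measured number rather than a limit. Nothing measured here gives a cause for this step.

Among the compounds shown here, the single step swaps chain length, branching, stereocentres and fluorine together, so which of these carries the loss stays open. As far as these compounds go, how an amine at the chain end or a longer unbranched chain would compare in this assay also stays open.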